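A Diacylhydrazine in Place of the Chlorophenylhydrazide

The source may report more compounds than this note shows. Statements on the series, on what has been measured and on what is new or still open speak of the compounds shown alone.

Compound 1 `O=C(NNc1ccccc1Cl)c1ccc(NS(=O)(=O)c2cnc(O)nc2O)cc1` is the only one of the three measured compounds that returns a number in a functional assay on SGC-7901 cells (Homo sapiens) for antiproliferative activity, read by MTT assay, with a stated time of 24 h; on this read-out lower numbers stand for stronger inhibition and higher numbers for weaker inhibition: compound 1 gives 3630 nM. Compound 2 `Cc1ccccc1NNC(=O)c1ccccc1NS(=O)(=O)c1cnc(O)nc1O` sits at a limit of the assay rather than at a number, giving > 20000 nM in this assay. Compound 3 `O=C(NNc1ccccc1Cl)c1ccccc1NS(=O)(=O)c1cnc(O)nc1O` likewise sits at a limit, with > 20000 nM in this assay. Going by the values given here, the one step between measured neighbours, a step that the two limits leave unreadable from compound 2 to compound 3, cannot be read in size, since both of its ends rest on (the limit of > 20000 nM in this assay, at which 2 of the 3 values shown sit).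

Compound 4 `O=C(NNC(=O)c1ccc(NS(=O)(=O)c2cnc(O)nc2O)cc1)c1ccc(F)cc1` differs from compound 1 by (4-fluorophenyl)carbonyl in place of 2-chlorophenyl on an amine nitrogen; cut one bond further out, the change reads (2-chlorophenyl)amino to ((4-fluorophenyl)carbonyl)amino. Among the compounds with values here, no measured step touches this kind of change: the only step available, between compound 2 and compound 3, alters a substituent on an aromatic ring and its size is not readable. With nothing to guide the direction, the estimate rests on a single measured neighbour, and a 1.4-fold higher number from compound 1 to compound 4 (0.14 log units; within the scatter) is expected to be small against a wide uncertainty. Compound 4 is estimated at 5000 nM, in a range from 1500 nM to 20000 nM.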

Compound 4, half-maximal inhibitory concentration: > 20000 nM
Compound 4: no number, only a limit; the forecaster's own chance of this, stated with the estimate: 30%; middle value at least 4.0-fold (0.60 log units) from the limit.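

On this amine nitrogen, (4-fluorophenyl)carbonyl in place of 2-chlorophenyl gives an at least 5.5-fold higher number from compound 1 to compound 4 (0.74 log units; beyond the scatter) in this assay and is clearly not a neutral swap. Going by these compounds alone, this is the first step whose size can be read at all, even if only as a minimum, and it shows that the antiproliferative read-out responds to what sits at this place, something the earlier compounds could not show. Within the data shown here, compound 1 remains the only compound here with an actual number, while the others all rest on the same limit of the assay, which is not a number: the limit of > 20000 nM in this assay, at which 3 of the 4 values shown sit.

The carbonyl and the fluorine-bearing ring enter together in this one change, and the compounds shown do not separate the contribution of either part, nor do they give the full size of the step. A 4-fluorophenyl group placed directly on this nitrogen, an unsubstituted benzoyl group or a small acetyl group would each be needed to tell whether the carbonyl, the fluorine or the larger group as a whole goes with the weaker result.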